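The source may hold more compounds than are shown below. What is called first, only, known or untested is meant among the compounds shown, and "the series" means these compounds.

Compound 1 `Cc1nc(N(C)c2ccc([Se]C#N)c(Cl)c2)c2ccccc2n1` stands lowest of the three numbers in a functional assay on HCT-116 cells (Homo sapiens) for inhibition, read by MTT assay, with a stated time of 48 h (a higher number here means a weaker inhibitor, a lower number a stronger inhibitor), giving 12 nM; compound 3 `COc1ccc(N(C)c2nc(C)nc3ccccc23)cc1OCCCCC[Se]C#N` gives 256 nM and compound 2 `COc1ccc(N(C)c2nc(C)nc3ccccc23)cc1C(=O)OCCC[Se]C#N` gives 720 nM. Compound 4 `Cc1nc(N(C)c2ccc([Se]C#N)c(F)c2)c2ccccc2n1` differs from compound 1 by a single change: fluoro in place of chloro on an aromatic carbon. Within the data shown here, the one measured step, a 2.8-fold lower number from compound 2 to compound 3 (0.45 log units; beyond the scatter), concerns a chain on the shared core and leaves the halogen untouched, so no measured step bears directly on this swap. With nothing to guide it, the step is expected to stay within the scatter, as the estimated 1.3-fold higher number from compound 1 to compound 4 (0.10 log units; within the scatter) shows. Compound 4 is therefore estimated at 15 nM, with a range from 5 nM to 45 nM that allows for the usual spread of such measurements.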

Compound 4, half-maximal inhibitory concentration: 20 nM
Compound 4: the middle estimate sits 1.3-fold (0.12 log units) below what was measured; the measured number falls inside the stated range.
By their numbers in this assay, from the lowest: compounds 1 and 4 (each within the scatter of the next); then compound 3; then compound 2.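

Replacing chloro with fluoro on this aromatic carbon gives a 1.7-fold higher number from compound 1 to compound 4 (0.22 log units; within the scatter) in this assay. At this place, then, the smaller of the two halogens serves as well as the larger one, and the chloro itself is not needed to keep the number this low. Nothing available explains why the two halogens read alike here.

Only these two halogens are shown at this place. Going by these compounds, how plain hydrogen, an amine or a carboxylic acid would read there remains open.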